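The compounds below may be only part of what the source reports. "The series", "measured", "known", "first", "only" and "open" are said of these compounds alone.

Measured so far:
Compound 1, `C=CCn1nc(-c2cccnc2)c2ccccc2c1=O`, gives 70% in an assay on isolated protein (Oryctolagus cuniculus) with Thromboxane-A synthase (Homo sapiens) as the target, tested at 1 uM; on this read-out higher numbers stand for more inhibition at the one concentration tested (going by the name of the read-out) and lower numbers for less inhibition.
Compound 2, `CC(=O)Cn1nc(-c2cccnc2)c2ccccc2c1=O`, gives 13% in this assay.

Going by the values given here, compound 1 stands highest of the two numbers measured, and only one step connects them: a number 57 percentage points lower from compound 1 to compound 2 (beyond the scatter). That step changed the group on the saturated chain carbon bound to an aromatic nitrogen, the same place that is changed in the new compound. Compound 3, `NCCn1nc(-c2cccnc2)c2ccccc2c1=O`, differs from compound 1 by aminomethyl in place of vinyl on a saturated chain carbon bound to an aromatic nitrogen.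

Among the compounds with values here, the one step that bears on this change is the large drop a number 57 percentage points lower from compound 1 to compound 2 (beyond the scatter), which shows that replacing the vinyl at this place can cost much inhibition. Aminomethyl is a different group from acetyl, so the size is uncertain, but a drop is the expectation, estimated as a number 45 percentage points lower from compound 1 to compound 3 (beyond the scatter). Compound 3 is therefore expected to give about 25% in this assay, within a range from 5% to 55%.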

Compound 3, a percentage reported as inhibition, at one concentration (the size of the read-out at that concentration, not a potency): 29%
Beside the measured number, compound 3's estimate is 4 percentage points below it; measured number inside the range.
By their numbers in this assay, from the lowest: compound 2; then compound 3; then compound 1.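

A second replacement at this place, on a saturated chain carbon bound to an aromatic nitrogen, also costs much of the inhibition in this assay: allyl to 2-aminoethyl gives a number 41 percentage points lower from compound 1 to compound 3 (beyond the scatter). The earlier fall is therefore not special to the acetyl, as two different groups in place of vinyl both stand lower than compound 1. The two replacements are not equal, though: aminomethyl in place of acetyl gives a number 16 percentage points higher from compound 2 to compound 3 (beyond the scatter), so the choice of group still moves the number among those that fall short of compound 1.

Nothing available here gives a reason for this order among the three compounds. From the compounds shown here alone, whether a propyl group, a longer chain ending in an amine, or a carboxylic acid at this place could match compound 1 remains open.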